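The compounds below may be only part of what the source reports. "The series", "measured", "known", "first", "only" and "open" are said of these compounds alone.

Compound 1, `COc1ccc(N2CCN(Cc3csc(N)c3C(=O)c3ccc(Cl)cc3)CC2)cc1`, in an assay on CHO cells for displacement of a labelled ligand from adenosine receptor A1 (Homo sapiens), read by scintillation counting, with a stated time of 120 min, tested at 10 uM (a lower number here means less inhibition, a higher number more inhibition at the concentration tested (going by the name of the read-out)), gives 0%.
Compound 2, `Nc1scc(CN2CCN(c3ccc([N+](=O)[O-])cc3)CC2)c1C(=O)c1ccc(Cl)cc1`, gives 1%.
Compound 3, `Nc1scc(CN2CCN(c3ccc(F)c(Cl)c3)CC2)c1C(=O)c1ccc(Cl)cc1`, gives 0%.

Compound 3 stands level with compound 1 at the digits printed, and the two together are the lowest of the three numbers; its nearest neighbour is compound 1, with no change at the digits printed from compound 1 to compound 3 (within the scatter), and its furthest is compound 2, with a number 1 percentage points lower from compound 2 to compound 3 (within the scatter). Both of these steps change the aryl group on the amine nitrogen in the ring, and neither moves the read-out beyond the scatter; the same is true of a number 1 percentage points higher from compound 1 to compound 2 (within the scatter).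

Compound 4, `Nc1scc(CN2CCN(c3ccccc3Cl)CC2)c1C(=O)c1ccc(Cl)cc1`, differs from compound 3 by 2-chlorophenyl in place of 3-chloro-4-fluorophenyl on an amine nitrogen in a ring. This is again a change of the aryl group on the amine nitrogen in the ring, the place where the measured steps showed nothing beyond the scatter. Compound 4 is therefore expected to move by a number 2 percentage points higher from compound 3 to compound 4 (within the scatter), a step not expected to exceed the scatter. The estimate for compound 4 is 2%, with a range from -5% to 10%.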

Compound 4, a percentage reported as inhibition, at one concentration (the size of the read-out at that concentration, not a potency): 2%
Compound 4: the middle estimate sits on the measured number at the digits printed; the measured number falls inside the stated range.
By their numbers in this assay, from the lowest: compounds 1, 3, 2 and 4 (each within the scatter of the next).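

With 2-chlorophenyl on the amine nitrogen in the ring, the series gains its first aryl group with a substituent numbered 2 rather than 3 or 4, and this assay shows a number 2 percentage points higher from compound 3 to compound 4 (within the scatter) and a number 1 percentage points higher from compound 2 to compound 4 (within the scatter) and a number 2 percentage points higher from compound 1 to compound 4 (within the scatter) as its steps. The read-out at this place therefore stays within the scatter for this change as well, so all four aryl groups shown read alike at the concentration tested. No measurement available here offers any explanation for this.

As far as these compounds go, all four compounds keep an aryl group at this place, so it remains open whether an open-chain amine, a carboxylic acid or a longer chain there would read differently. From the compounds shown here alone, the 4-chlorophenyl group and the free amine of the shared core also stay the same throughout, so changes at those places remain open too.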